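The compounds below may be only part of what the source reports. "The series", "measured", "known", "first", "only" and "open" are said of these compounds alone.

Working notes on the series. In an ADME assay on the whole organism (Rattus norvegicus, strain Sprague-Dawley) for pharmacokinetics, read by LC-MS, with a stated time of 30 min, at a dose of 1 mg/kg by the intravenous route (on this read-out higher numbers stand for fast clearance and lower numbers for slow clearance), compound 1 (`N#Cc1ccc(O[C@H]2CN(S(=O)(=O)c3ccc(C(F)(F)F)cc3)C[C@@]2(O)CO)cc1F`) gives 50 mL/min/kg. Compound 2 (`N#Cc1ccc(O[C@H]2CN(S(=O)(=O)c3ccc(Cl)cc3Cl)C[C@@]2(O)CN)cc1F`) gives 40 mL/min/kg, and compound 3 (`N#Cc1ccc(O[C@H]2CN(S(=O)(=O)c3ccc(Cl)cc3Cl)C[C@]2(O)CO)cc1F`) gives 54 mL/min/kg. Going by the values given here, compound 1 therefore stands within the scatter of both other compounds, and no measured pair differs in only one place. Compound 4 (`N#Cc1ccc(O[C@H]2CN(S(=O)(=O)c3ccc(Cl)cn3)C[C@@]2(O)CO)cc1F`) carries 5-chloropyridin-2-yl in place of 4-(trifluoromethyl)phenyl on a sulfonyl sulfur. The three measured compounds do not all share one group at that sulfur, yet their values stay within the scatter, so no change beyond the scatter is expected in this assay. The expected change is a 1.2-fold lower number from compound 1 to compound 4 (0.08 log units; within the scatter). Compound 4 is estimated at 42 mL/min/kg, with an expected range of 24 mL/min/kg to 70 mL/min/kg.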

Compound 4, clearance in the Rattus norvegicus assay: 30 mL/min/kg
Compound 4: middle estimate off by 1.4-fold (0.15 log units), on the high side; measured number inside the range.
By their numbers in the Rattus norvegicus assay, from the lowest: compounds 4, 2, 1 and 3 (each within the scatter of the next).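

In the Rattus norvegicus assay, the only one-place step shown at this sulfonyl sulfur is a 1.7-fold lower number from compound 1 to compound 4 (0.22 log units; within the scatter), so putting 5-chloropyridin-2-yl in place of 4-(trifluoromethyl)phenyl leaves clearance within the scatter. In a physicochemical assay for lipophilicity, at pH 7.4 (a lower number here means a more polar compound, a higher number a more lipophilic compound), compound 1 gives 4.5 and compound 4 gives 3.4 here. In the physicochemical assay, the same change moves the read-out well beyond the scatter, while clearance shows no step beyond it: the measured distribution coefficient of compound 1, 4.5, and of compound 4, 3.4, a number 1.10 log units lower (beyond the scatter)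

A single pair cannot show whether the two read-outs are linked at this position. Also open, going by these compounds, is how clearance responds to an aromatic ring bearing an amine or a carboxylic acid on this sulfonyl sulfur.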